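Fluoro for Methoxy on a Triazole-Linked Aryl Pair

The source may hold more compounds than are shown below. What is called first, only, known or untested is meant among the compounds shown, and "the series" means these compounds.

Measured compounds:
compound 1, `COc1ccc(-c2ncnn2-c2cc(OC)c(OC)c(OC)c2)cc1`: 50 nM
compound 2, `COc1cc(-c2ncnn2-c2ccc(F)cc2)cc(OC)c1OC`: > 10000 nM

Of the compounds shown here, two have been measured in a functional assay on Jurkat cells (Homo sapiens) for antiproliferative activity, read by MTT assay, with a stated time of 72 h; on this read-out higher numbers stand for weaker inhibition and lower numbers for stronger inhibition. Among the measured compounds shown here, compound 1, `COc1ccc(-c2ncnn2-c2cc(OC)c(OC)c(OC)c2)cc1`, holds the only finite number, giving 50 nM in this assay. Compound 2, `COc1cc(-c2ncnn2-c2ccc(F)cc2)cc(OC)c1OC`, is reported only as a limit of this assay, > 10000 nM, and not as a number; this is the limit of > 10000 nM in this assay, at which 1 of the 2 values shown sits. Compound 2 differs from compound 1 in more than one place, so the two values are set side by side without a step between them.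

Compound 3, `COc1cc(-n2ncnc2-c2ccc(F)cc2)cc(OC)c1OC`, is not yet measured. It differs from compound 1 by fluoro in place of methoxy on an aromatic carbon, and from compound 2 only in the way the two aryl groups are attached to the shared core. For the measured compounds named here, no measured step of this kind is available, so the expectation rests on compound 1 alone. The step from compound 1 to compound 3 in this assay is expected to be a 10-fold higher number from compound 1 to compound 3 (1.00 log units; beyond the scatter), toward weaker inhibition and beyond the scatter. Compound 3 is thus estimated at 500 nM, with a range from 100 nM to 5000 nM.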

Compound 3, half-maximal inhibitory concentration: > 10000 nM
Compound 3: only a limit was reported (the forecaster's own chance of this, stated with the estimate: 15%); middle value at least 20-fold (1.30 log units) from the limit.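

In this assay, among the compounds shown here, compound 3 gives the first comparison in which only one place changes, and going from 4-methoxyphenyl to 4-fluorophenyl on the core of compound 1 produces an at least 200-fold higher number from compound 1 to compound 3 (2.30 log units; beyond the scatter). The value of compound 3, > 10000 nM, is a limit of the assay and not a number. The activity seen with compound 1 therefore does not survive fluoro in place of methoxy at this position, and with fluoro present, the way the two aryl groups are attached cannot be read, so no step from compound 2 to compound 3 can be given: the limit of > 10000 nM in this assay, at which 2 of the 3 values shown sit.

The compounds shown leave open whether other groups at this position, such as hydroxyl, chloro, methyl, ethoxy or an amine, would keep the activity of compound 1 or would also reach the limit. From the compounds shown here alone, they also leave open how the attachment found in compound 2 would behave with the 4-methoxyphenyl group in place, so the effect of attachment remains unknown while methoxy is present.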